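The source may hold more compounds than are shown below. What is called first, only, known or untested is meant among the compounds shown, and "the series" means these compounds.

Measured so far:
compound 1 `Cc1c(OCCCCOc2cccc(C(=O)O)c2)ccc(C(=O)CC(C)C)c1C` — 18.3%
compound 2 `Cc1c(OCCCCOc2ccc(F)c(C(=O)O)c2)ccc(C(=O)CC2CCCC2)c1O` — 98.4%
compound 3 `COC(=O)c1ccc(OCCCCOc2ccc(C(=O)CC3CCCC3)c(C)c2C)cc1` — 24.2%

In an assay on HEK293 cells for positive allosteric modulation of metabotropic glutamate receptor 3 (Rattus norvegicus), read by thallium flux, with a stated time of 2.5 min (a lower number here means a smaller maximal response, a higher number a larger maximal response), compound 1 gives 18.3%, the lowest of the three numbers. Compound 3 with 24.2% lies within the scatter of compound 1, whereas compound 2 with 98.4% lies far beyond it. Compound 4 `Cc1c(OCCCCOc2cccc(C(=O)O)c2)ccc(C(=O)CC(C)C)c1O` is not yet measured. It differs from compound 1 in one place: hydroxy in place of methyl on an aromatic carbon. For the measured compounds named here, no step between measured compounds isolates this change; compound 2, the only measured compound carrying a hydroxy group, also differs from compound 1 elsewhere. In this assay an upward step beyond the scatter is expected, of uncertain size. For compound 4 the estimate in this assay is 60%, with a range of 25% to 95%. The expected step is a number 41.7 percentage points higher from compound 1 to compound 4 (beyond the scatter).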

Compound 4, largest response reached (reported as percent of maximum), in percent of the reference or control that the assay uses: 69.9%
Beside the measured number, compound 4's estimate is 9.9 percentage points below it; the measured number falls inside the stated range.
By their numbers in this assay, from the lowest: compounds 1 and 3 (each within the scatter of the next); then compound 4; then compound 2.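

In this assay, hydroxy in place of methyl on the aromatic carbon ortho to the isobutylcarbonyl group gives a number 51.6 percentage points higher from compound 1 to compound 4 (beyond the scatter) and is the only difference between the two structures. For the compounds shown here, this single change on the core of compound 1 is therefore enough for a large rise in maximal response, which no earlier pair could isolate. No measurement here gives a reason for the step. Still open, as far as these compounds go, is whether a methoxy group or an amine in the same place gives a similar step, and whether the step holds with other ketone side chains.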